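Aryl variation on the benzylic amine: compound 4

The source may hold more compounds than are shown below. What is called first, only, known or untested is meant among the compounds shown, and "the series" means these compounds.

Going by the values given here, in a functional assay on MIA PaCa-2 cells (Homo sapiens) for inhibition, read by MTT assay, with a stated time of 72 h (on this read-out higher numbers stand for weaker inhibition of growth and lower numbers for stronger inhibition of growth), compound 3 `O=S(=O)(NCCCNCc1cccc2ccccc12)c1cc(C(F)(F)F)cc(C(F)(F)F)c1` gives 2800 nM, the second highest of the three numbers so far. Compound 1 `CC(C)(C)c1ccc(CNCCCNS(=O)(=O)c2cc(C(F)(F)F)cc(C(F)(F)F)c2)cc1` gives 2300 nM, and compound 2 `O=S(=O)(NCCCNCc1ccc(Cl)c(C(F)(F)F)c1)c1cc(C(F)(F)F)cc(C(F)(F)F)c1` gives 7400 nM. The step of a 1.2-fold higher number from compound 1 to compound 3 (0.09 log units; within the scatter) lies within the scatter, while a 2.6-fold lower number from compound 2 to compound 3 (0.42 log units; beyond the scatter) is modest. Compound 4 `COc1ccccc1CNCCCNS(=O)(=O)c1cc(C(F)(F)F)cc(C(F)(F)F)c1` differs from compound 3 by 2-methoxyphenyl in place of naphthalen-1-yl on a saturated chain carbon bound to an amine nitrogen. Among the compounds with values here, every measured step so far swaps the aryl group at this same place, the widest being a 3.2-fold higher number from compound 1 to compound 2 (0.51 log units; beyond the scatter), so another aryl swap is expected to shift the number only modestly, if beyond the scatter at all, and more likely toward a higher number. Compound 4 is estimated at 3500 nM, with a range of 1500 nM to 9000 nM, which is the expected step of a 1.3-fold higher number from compound 3 to compound 4 (0.10 log units; within the scatter).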

Compound 4, concentration for 50% growth inhibition: 3100 nM
The estimate for compound 4 lay 1.1-fold (0.05 log units) above the measured number, and the stated range covers the measured number.
By their numbers in this assay, from the lowest: compounds 1, 3 and 4 (each within the scatter of the next); then compound 2.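

In this assay the single-ring 2-methoxyphenyl, which brings one hydrogen-bond acceptor, stays within the scatter of the two-ring naphthalen-1-yl (a 1.1-fold higher number from compound 3 to compound 4 (0.04 log units; within the scatter)) and of 4-(tert-butyl)phenyl (a 1.3-fold higher number from compound 1 to compound 4 (0.13 log units; within the scatter)). At this place, neither ring count nor the acceptor separates these compounds, and only 4-chloro-3-(trifluoromethyl)phenyl stands apart (a 2.4-fold lower number from compound 2 to compound 4 (0.38 log units; beyond the scatter)). No measurement here bears on what lies behind these steps.

Still open, from the compounds shown here alone, is whether a saturated ring such as cyclohexyl or a nitrogen-containing ring such as pyridin-3-yl would hold the number at this place. Going by these compounds, a longer chain in the linker is equally open.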